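The source may hold more compounds than are shown below. What is called first, only, known or untested is meant among the compounds shown, and "the series" means these compounds.

Compound 3 `O=C(/C(=C\c1ccc(F)cc1)S(=O)(=O)c1ccc(Br)cc1)c1ccc(Br)cc1` is one of three compounds tested in a functional assay on DU-145 cells (Homo sapiens) for inhibition, read by trypan blue exclusion, with a stated time of 96 h (on this read-out lower numbers stand for stronger inhibition of growth and higher numbers for weaker inhibition of growth), where compound 3 gives 4000 nM. That number is the second highest of the three. Compound 1 `O=C(/C(=C\c1ccc(Cl)cc1Cl)Sc1ccc(Br)cc1)c1ccc(Br)cc1` gives 1000 nM, and compound 2 `O=C(/C(=C\c1ccc(OC(F)(F)F)cc1)S(=O)(=O)c1ccc(Br)cc1)c1ccc(Br)cc1` gives 25000 nM, the highest of the set. Within the data shown here, the one measured step, a 6.3-fold lower number from compound 2 to compound 3 (0.80 log units; beyond the scatter), shows that changing the aromatic ring on the double-bonded chain carbon can move the number by a modest amount.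

Compound 4 `COc1cccc(OC)c1/C=C(\C(=O)c1ccc(Br)cc1)S(=O)(=O)c1ccc(Br)cc1` differs from compound 3 by 2,6-dimethoxyphenyl in place of 4-fluorophenyl on a double-bonded chain carbon bound to a double-bonded chain carbon. Among the measured compounds shown here, only the step from compound 2 to compound 3 bears on a change at this ring, and it concerned fluoro and trifluoromethoxy, not two methoxy groups, so the direction is uncertain. For compound 4 an expected step of a 2.0-fold higher number from compound 3 to compound 4 (0.30 log units; within the scatter) is taken, a modest rise, giving an estimate of 8000 nM with a range from 2000 nM to 30000 nM.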

Compound 4, concentration for 50% growth inhibition: 10000 nM
For compound 4 the middle estimate is 1.3-fold (0.10 log units) below the measured one; the range from low to high includes it.
By their numbers in this assay, from the lowest: compound 1; then compound 3; then compound 4; then compound 2.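

Changing 4-fluorophenyl to 2,6-dimethoxyphenyl gives a 2.5-fold higher number from compound 3 to compound 4 (0.40 log units; beyond the scatter), so this position tolerates a ring with two methoxy groups at only a modest cost. Compound 4 also keeps a lower number than compound 2 at 25000 nM, so the ring substituents shown so far do not all cost the same. Nothing available explains this step.

The compounds shown leave open whether a single methoxy group would match the pair in compound 4. They also leave open whether an amine or a carboxylic acid on this ring would lower the number.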